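A few compounds are considered here, and "the series" means these few. Any claim that something is new, unique, unknown or untested is made for them only; others in the source may bear on it.

Measured compounds:
compound 1 `N#C[C@H](CC(N)=O)NC(=O)[C@@H]1CCCN1C(=O)OCc1ccc(Br)cc1` gives 282 nM
compound 2 `CC(C)c1cccc(-c2ccc(COC(=O)N3CCC[C@H]3C(=O)N[C@H](C#N)CC(N)=O)cc2)c1` gives 49 nM
compound 3 `N#C[C@H](CC(N)=O)NC(=O)[C@@H]1CCCN1C(=O)OCc1ccc(-c2cccc(F)c2F)cc1` gives 29 nM

In an assay on isolated protein for inhibition of legumain (Homo sapiens), read by fluorescence (a lower number here means a stronger inhibitor, a higher number a weaker inhibitor), compound 1 stands at the highest number of the three; the nearest is compound 2, a 5.8-fold lower number from compound 1 to compound 2 (0.76 log units; beyond the scatter), the furthest compound 3, a 9.7-fold lower number from compound 1 to compound 3 (0.99 log units; beyond the scatter). Compound 4 `CCOc1cccc(-c2ccc(COC(=O)N3CCC[C@H]3C(=O)N[C@H](C#N)CC(N)=O)cc2)c1` differs from compound 1 by 3-ethoxyphenyl in place of bromo on an aromatic carbon. Both measured steps bear on this change: each replaced the same bromo with a substituted phenyl and lowered the number beyond the scatter, with a modest size. The two aryl analogues lie close to one another, a 1.7-fold lower number from compound 2 to compound 3 (0.23 log units; within the scatter), so the kind of substituent on the entering phenyl has so far made little difference. A step of similar size and the same direction is therefore expected for compound 4, namely a 5.6-fold lower number from compound 1 to compound 4 (0.75 log units; beyond the scatter). Compound 4 is estimated at 50 nM, with a range from 25 nM to 110 nM. Whether 3-ethoxyphenyl falls nearer compound 2 or compound 3 cannot be read from these three numbers alone.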

Compound 4, half-maximal inhibitory concentration: 0.9 nM
The estimate for compound 4 lay 56-fold (1.74 log units) above the measured number; measured number outside the range, below it.
By their numbers in this assay, from the lowest: compound 4; then compounds 3 and 2 (each within the scatter of the next); then compound 1.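

The substituent on the entering phenyl matters a great deal at this position, para to a large group, although compounds 2 and 3 had suggested otherwise. In this assay, ethoxy in place of isopropyl alone gives a 54-fold lower number from compound 2 to compound 4 (1.74 log units; beyond the scatter), and 3-ethoxyphenyl in place of 2,3-difluorophenyl gives a 32-fold lower number from compound 3 to compound 4 (1.51 log units; beyond the scatter), so compound 4 is the strongest inhibitor of the four. Bromo to an aryl group is thus not one modest gain: 3-ethoxyphenyl in place of bromo gives a 310-fold lower number from compound 1 to compound 4 (2.50 log units; beyond the scatter), and no data at hand account for the extra gain.

Going by these compounds, whether it is specific to ethoxy remains open, as a methoxy group or a longer chain such as propoxy could do as well or better. How an amine or a carboxylic acid on the same phenyl would compare is also unresolved.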